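This account rests on a few compounds, and the source may have more. Where it says the series, first, only, none or still open, it means among the compounds named here.

Compound 1 `Fc1ccc(Nc2nc(-c3cccc(F)c3)nc3ccc(F)cc23)cc1`: > 50000 nM
Compound 2 `Fc1cccc(-c2nc(Nc3ccc(Br)cc3)c3cc(F)ccc3n2)c1`: > 50000 nM
Compound 3 `Fc1cccc(-c2nc(Nc3ccccc3Br)c3cc(F)ccc3n2)c1`: > 50000 nM

These entries come from a functional assay on U-937 cells (Homo sapiens) for cytotoxicity, read by MTT assay, with a stated time of 48 h (on this read-out lower numbers stand for stronger inhibition and higher numbers for weaker inhibition), and each one is a limit of the assay and not a number. Compound 3 stands at such a limit, with > 50000 nM. The same holds for the whole set, as the limit of > 50000 nM in this assay, at which 3 of the 3 values shown sit, shows.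

The next structure is compound 4 `Nc1ccc(Nc2nc(-c3cccc(F)c3)nc3ccc(F)cc23)cc1`, which carries 4-aminophenyl in place of 2-bromophenyl on a nitrogen on an aromatic ring. The measured steps nearest to this change alter the group at that same place: a step that the two limits leave unreadable from compound 1 to compound 3 and a step that the two limits leave unreadable from compound 2 to compound 3. The remaining one is a step that the two limits leave unreadable from compound 1 to compound 2. None of them has a readable size, so they offer no measured size to carry over. Compound 4 is expected to stay at the same limit in this assay, and any number it does give is expected on the stronger side of that limit. The estimated change is an at least 1.2-fold lower number from compound 3 to compound 4 (0.09 log units; that floor lies within the scatter), and it is only a rough expectation. For compound 4 the expected value is 40000 nM, with an estimated range from 15000 nM to 50000 nM.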

Compound 4, half-maximal inhibitory concentration: > 50000 nM
Compound 4 gave a limit, no number; the forecaster's own chance of this, stated with the estimate: 65%; at least 1.2-fold (0.09 log units) between middle value and limit.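

Compound 4 gives > 50000 nM, which is a limit and not a number. No new step from compound 1, compound 2 or compound 3 to compound 4 can be read, because all four compounds sit at a limit: the limit of > 50000 nM in this assay, at which 4 of the 4 values shown sit.

The compounds shown leave open whether any change of the group on the nitrogen would give a readable number at all.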